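The source may hold more compounds than are shown below. What is called first, only, known or untested is meant among the compounds shown, and "the series" means these compounds.

Going by the values given here, compound 1 `CC1=NC(C)=C([N+](=O)[O-])C(c2ncccc2C)/C1=C(/O)OCCc1ccccc1` gives 5430 nM in a functional assay (muscle tissue) with Cavia porcellus as the target (a lower number here means a stronger inhibitor, a higher number a weaker inhibitor), the highest of the two numbers so far. Compound 2 `CC1=NC(C)=C([N+](=O)[O-])C(c2cccc([N+](=O)[O-])n2)/C1=C(/O)OCCc1ccccc1` gives 4740 nM in this assay, and the exchange from compound 1 to compound 2 gave a 1.1-fold lower number from compound 1 to compound 2 (0.06 log units; within the scatter). Compound 3 `CC1=NC(C)=C([N+](=O)[O-])C(c2ncccc2-c2ccccc2)/C1=C(/O)OCCc1ccccc1` differs from compound 1 by phenyl in place of methyl on an aromatic carbon. Among the compounds with values here, no measured step covers this exchange; the one step at hand, a 1.1-fold lower number from compound 1 to compound 2 (0.06 log units; within the scatter), altered the same 3-methylpyridin-2-yl group and stayed within the scatter, so nothing beyond the scatter is expected in either direction. For compound 3 the estimate is 5000 nM, between 1500 nM and 16000 nM, an expected step of a 1.1-fold lower number from compound 1 to compound 3 (0.04 log units; within the scatter).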

Compound 3, half-maximal inhibitory concentration: 3350 nM
Estimate against measurement, compound 3: 1.5-fold (0.17 log units) above, and the stated range covers the measured number.
By their numbers in this assay, from the lowest: compounds 3, 2 and 1 (each within the scatter of the next).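

On an aromatic carbon two atoms from the ring nitrogen, phenyl in place of methyl brings in a whole six-membered aromatic ring of carbon only, yet in this assay the result is a 1.6-fold lower number from compound 1 to compound 3 (0.21 log units; within the scatter). This position therefore accepts six heavy atoms in place of one with no step beyond the scatter. No available evidence bears on this result. On these data alone, whether an amine, a carboxylic acid or a longer chain on this aromatic carbon would give a step beyond the scatter remains open.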